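This account rests on a few compounds, and the source may have more. Where it says the series, first, only, none or still open, it means among the compounds named here.

Compound 1 `C/C(=C\CC/C(C)=C/CC[C@@H]1[C@@]2(C)CCC(=O)C(C)(C)[C@H]2CC[C@@]1(C)O)CC/C=C(\C)C(=O)OCc1cn(-c2ccccc2[N+](=O)[O-])nn1` gives in a functional assay on A549 cells (Homo sapiens) for antiproliferative activity, read by MTT assay, with a stated time of 48 h (on this read-out higher numbers stand for weaker inhibition and lower numbers for stronger inhibition), only a limit, > 150000 nM.
Compound 2 `C/C(=C\CC/C(C)=C/CC[C@@H]1[C@@]2(C)CCC(=O)C(C)(C)[C@H]2CC[C@@]1(C)O)CC/C=C(\C)C(=O)OCc1cn(-c2ccc(C(C)(C)C)cc2)nn1` gives in this assay only a limit, > 150000 nM.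

Compound 2 therefore stands at the edge of what this assay reports, not at a number. Within the data shown here, the one measured step, a step that the two limits leave unreadable from compound 1 to compound 2, cannot be read, because of the limit of > 150000 nM in this assay, at which 2 of the 2 values shown sit. Compound 3 `C/C(=C\CC/C(C)=C/CC[C@@H]1[C@@]2(C)CCC(=O)C(C)(C)[C@H]2CC[C@@]1(C)O)CC/C=C(\C)C(=O)OCc1cn(-c2cccc(C(F)(F)F)c2)nn1` differs from compound 2 by 3-(trifluoromethyl)phenyl in place of 4-(tert-butyl)phenyl on an aromatic nitrogen. Among the measured compounds shown here, no measured step bears on this change, so no shift beyond the scatter is expected in either direction. Compound 3 is expected to sit near 150000 nM, within 50000 nM to 400000 nM, most likely again as a limit. The expected step is a number no higher from compound 2 to compound 3 (the limit leaves the size open).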

Compound 3, half-maximal inhibitory concentration: > 150000 nM
Compound 3 gave a limit, no number; the forecaster's own chance of this, stated with the estimate: 75%; the middle value sits exactly at the limit.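

Among these compounds, no step between compound 1, compound 2 and compound 3 can be read, because each result is a limit and not a number: the limit of > 150000 nM in this assay, at which 3 of the 3 values shown sit.

The compounds shown leave open how the 2-nitrophenyl, 4-(tert-butyl)phenyl and 3-(trifluoromethyl)phenyl groups rank against one another in this assay.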